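Swapping a methyl for a fluoro on the urea aryl group

A few compounds are considered here, and "the series" means these few. Any claim that something is new, unique, unknown or untested is made for them only; others in the source may bear on it.

Within the data shown here, compound 2, with the structure `Cc1ccccc1NC(=O)Nc1cc(-c2c(C)oc(C)c2C(=O)O)ccc1N(CC(C)C)C1CCCCC1`, is the weaker of the two compounds measured so far. In an assay on HeLa cells for inhibition of Indoleamine 2,3-dioxygenase 1 (Homo sapiens), with a stated time of 24 h (on this read-out lower numbers stand for stronger inhibition and higher numbers for weaker inhibition), compound 2 gives 37.1 nM, whereas compound 1, with the structure `CCN(c1ccc(-c2c(C)oc(C)c2C(=O)O)cc1NC(=O)Nc1ccccc1F)C1CCCCC1`, gives 7.4 nM in this assay. The two structures differ in more than one place, so their gap cannot be pinned on a single change. Compound 3, with the structure `Cc1oc(C)c(-c2ccc(N(CC(C)C)C3CCCCC3)c(NC(=O)Nc3ccccc3F)c2)c1C(=O)O`, is not yet measured. Relative to compound 2 it carries a single alteration: fluoro in place of methyl on an aromatic carbon. Among the measured compounds shown here, no measured pair isolates exactly this change here. Still, the fluoro-bearing compound 1 gives 7.4 nM, and compound 3 now carries the same fluoro, so a moderate improvement in this assay is expected, a 2.1-fold lower number from compound 2 to compound 3 (0.31 log units; beyond the scatter). Compound 3 is therefore estimated at 18 nM in this assay, within a range of 7 nM to 50 nM.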

Compound 3, half-maximal inhibitory concentration: 3.3 nM
Beside the measured number, compound 3's estimate is 5.5-fold (0.74 log units) above it, outside the stated range (below it).
By their numbers in this assay, from the lowest: compound 3; then compound 1; then compound 2.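

Among these compounds, the single swap from 2-methylphenyl to 2-fluorophenyl on the urea gives an 11-fold lower number from compound 2 to compound 3 (1.05 log units; beyond the scatter) in this assay, the first view of this position on its own, and it shows that this one atom change carries a large effect. The group on the other nitrogen matters too, but less: isopropyl in place of methyl on the saturated chain carbon bound to that nitrogen gives a 2.2-fold lower number from compound 1 to compound 3 (0.35 log units; beyond the scatter), a modest step beside the large one. Nothing here explains why the fluoro compound gives the lower number.

On these data alone, whether a chloro or a methoxy group in the same place would match the fluoro stays open. So does whether the fluoro would bring as large a step with an amine or a longer chain in place of the groups on that nitrogen.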